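This account rests on a few compounds, and the source may have more. Where it says the series, first, only, none or still open, it means among the compounds named here.

Measured so far in a functional assay on Ehrlich cells (Mus musculus) for cytotoxicity, read by trypan blue exclusion, with a stated time of 2 h, tested at 10 ug/mL; a lower number here means a weaker effect, a higher number a stronger effect of the compound at the concentration tested:
- compound 1 `Cc1ccc(C2C(C#N)=C(N)N(c3ccc(S(N)(=O)=O)cc3)C3=C2CCCC3)cc1`, where compound 1 gives 20%
- compound 2 `COc1ccc(C2C(C#N)=C(N)N(c3ccc(S(N)(=O)=O)cc3)C3=C2CCCC3)cc1`, where compound 2 gives 50%

Compound 2 stands highest of the two numbers; its nearest neighbour is compound 1, and the step of a number 30 percentage points higher from compound 1 to compound 2 (beyond the scatter) lies beyond the scatter. Compound 3 `N#CC1=C(N)N(c2ccc(S(N)(=O)=O)cc2)C2=C(CCCC2)C1c1ccccc1Cl` has not been measured. It differs from compound 2 in one place: 2-chlorophenyl in place of 4-methoxyphenyl on a saturated ring carbon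

Going by the values given here, only one measured step exists, the one from compound 1 to compound 2, and it changes the same aromatic ring on the saturated ring carbon, though by a different exchange of groups. That step is modest but beyond the scatter, so changes on this ring can move the number noticeably, while nothing shows in which direction a 2-chlorophenyl would move it. For compound 3 a step of a number 15 percentage points lower from compound 2 to compound 3 (beyond the scatter) in this assay is therefore expected, downward from the highest number but uncertain in sign. Compound 3 is estimated at 35%, with a range from 10% to 60%.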

Compound 3, a percentage reported as activity, at one concentration (the size of the read-out at that concentration, not a potency): 0%
Beside the measured number, compound 3's estimate is 35 percentage points above it; measured number outside the range, below it.
By their numbers in this assay, from the lowest: compound 3; then compound 1; then compound 2.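

In this assay, changes to the aromatic ring on the saturated ring carbon can also lower the number, and sharply: 2-chlorophenyl in place of 4-methoxyphenyl gives a number 50 percentage points lower from compound 2 to compound 3 (beyond the scatter), and 2-chlorophenyl in place of 4-methylphenyl gives a number 20 percentage points lower from compound 1 to compound 3 (beyond the scatter). The earlier pair showed only the exchange of one group for another at the same place on this ring, whereas these steps show that this single position, with the rest of the core unchanged, can span the whole range seen here, with compound 3 at the bottom at 0%. Nothing among the data shown explains why this exchange has such an effect.

The exchange in compound 3 changes both the group on the aromatic ring and its place on that ring, so the compounds shown cannot tell whether the chlorine or its place matters more. A 4-chlorophenyl and a 2-methoxyphenyl would separate these two changes, while an unsubstituted phenyl would show what the ring does without any added group.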